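Changing the Amide Aryl Group on a Shared Core

A few compounds are considered here, and "the series" means these few. Any claim that something is new, unique, unknown or untested is made for them only; others in the source may bear on it.

Compound 1 `O=C(/C=C/c1coc2cc(O)ccc2c1=O)NCc1ccccc1` gives > 100000 nM in a functional assay on HeLa cells (Homo sapiens) for inhibition, read by MTT assay, with a stated time of 48 h (a higher number here means a weaker inhibitor, a lower number a stronger inhibitor), which is a limit of the assay, not a number.
Compound 2 `COc1cccc(NC(=O)/C=C/c2coc3cc(OC)ccc3c2=O)c1` gives 19200 nM in this assay.
Compound 3 `O=C(/C=C/c1coc2cc(O)ccc2c1=O)NCc1ccc(F)cc1` gives > 100000 nM in this assay, again a limit rather than a number.

For the measured compounds named here, compound 2 holds the only real number here; the other two values are limits. Going by the values given here, the single measured step, a step that the two limits leave unreadable from compound 1 to compound 3, cannot be read because of the limit of > 100000 nM in this assay, at which 2 of the 3 values shown sit. Compound 4 `COc1ccc2c(=O)c(/C=C/C(=O)Nc3ccc(Cl)cc3)coc2c1` differs from compound 2 by 4-chlorophenyl in place of 3-methoxyphenyl on an amide-type nitrogen. Among the compounds with values here, no measured step touches the group on the amide-type nitrogen, so nothing measured guides this change. For compound 4 the expectation is no step beyond the scatter, a 1.0-fold higher number from compound 2 to compound 4 (0.02 log units; within the scatter). Compound 4 is therefore estimated at 20000 nM, in the range 5000 nM to 80000 nM.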

Compound 4, half-maximal inhibitory concentration: > 100000 nM
Compound 4 ended at the assay's limit; the forecaster's own chance of this, stated with the estimate: 20%; middle value at least 5.0-fold (0.69 log units) from the limit.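

The group on the amide-type nitrogen clearly matters: 4-chlorophenyl in place of 3-methoxyphenyl gives an at least 5.2-fold higher number from compound 2 to compound 4 (0.71 log units; beyond the scatter). For the compounds shown here, this is the first readable step in this assay, though only its minimum size is known. The value of compound 4 is a limit, not a number, and the same holds for most of this set: the limit of > 100000 nM in this assay, at which 3 of the 4 values shown sit.

The compounds shown cannot separate the effect of adding the chlorine from that of losing the methoxy group. From the compounds shown here alone, it also remains open whether a phenyl ring carrying an amine or a carboxylic acid would stay measurable, as compound 2 does at 19200 nM.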